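Replacing naphthalen-1-yl with 2-methoxyphenyl in a weakly active set

A few compounds are considered here, and "the series" means these few. Any claim that something is new, unique, unknown or untested is made for them only; others in the source may bear on it.

In a functional assay on PC-3 cells (Homo sapiens) for inhibition, read by sulforhodamine B assay, with a stated time of 48 h, tested at 50 uM (a higher number here means more inhibition of growth at the concentration tested, a lower number less inhibition of growth), compound 1 (`COc1cc(/C=C/C(=O)/C=C/c2cccc3ccccc23)ccc1OCc1cn(CCCCCOc2cc(=O)oc3ccccc23)nn1`) is recorded as "not active" (no number reported) with no figure attached, so it has no exact place on the numerical scale. Compound 3 (`COc1cc(/C=C/C(=O)/C=C/c2cccc3ccccc23)ccc1OCc1cn(CCCCOc2cc(=O)oc3ccccc23)nn1`) shares that outcome and is also recorded as "not active" (no number reported) without a number. Within the data shown here, the only number so far belongs to compound 2 (`COc1cc(/C=C/C(=O)/C=C/c2cccs2)ccc1OCc1cn(CCOc2cc(=O)oc3ccccc23)nn1`) at 12% of growth inhibition, a modest reading at the single concentration tested.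

Compound 4 (`COc1ccccc1/C=C/C(=O)/C=C/c1ccc(OCc2cn(CCCCCOc3cc(=O)oc4ccccc34)nn2)c(OC)c1`) has not yet been measured. It departs from compound 1 at one place, and the change is 2-methoxyphenyl in place of naphthalen-1-yl on a double-bonded chain carbon bound to a double-bonded chain carbon on a double-bonded chain carbon bound to a double-bonded chain carbon. Among the measured compounds shown here, no measured pair isolates this replacement, so the data give no size for it. In this assay only a small upward step from compound 1 is expected, one that may not clear the usual scatter. For the measured compounds named here, the expectation leans on the fact that the sole numerical reading is compound 2 at 12% and that nothing measured so far shows strong inhibition. Compound 4 is estimated at 10% within an expected range of 0% to 30% for the measurement to come.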

Compound 4, percent growth inhibition at one concentration: "not active" (no number reported)
Nothing numeric was reported for compound 4, so the estimate cannot be set against anything.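

Compound 1 and compound 4 both stand without a number in this assay, so no step can be read for the change from naphthalen-1-yl to 2-methoxyphenyl. Nothing shown here bears on this result. The compounds shown leave open whether that replacement changes growth inhibition at all, and by how much.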